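The source may report more compounds than this note shows. Statements on the series, on what has been measured and on what is new or still open speak of the compounds shown alone.

In a functional assay on PC-3 cells (Homo sapiens) for inhibition, read by MTT assay, with a stated time of 48 h (a lower number here means a stronger inhibitor, a higher number a weaker inhibitor), compound 3 `COc1cc(-c2nnc(SCC(=O)c3ccc(F)cc3)n2-c2ccc(N(C)C)cc2)cc(OC)c1OC` gives 42300 nM. Compound 2 `COc1ccc(C(=O)CSc2nnc(-c3cc(OC)c(OC)c(OC)c3)n2-c2ccc(N(C)C)cc2)cc1` gives 22000 nM, and the measured step, a 1.9-fold higher number from compound 2 to compound 3 (0.28 log units; within the scatter), leaves the two level within the scatter. Compound 3 therefore stands with compound 2 among the numerical values.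

Compound 1 `COc1ccc(-n2c(SCC(=O)c3ccc4ccccc4c3)nnc2-c2cc(OC)c(OC)c(OC)c2)cc1`, which also has naphthalen-2-yl on a carbonyl carbon, reports only a limit, > 60000 nM. Within the data shown here, no measured step links this limit to another compound, so it sets no size for the change considered here.

Compound 4 `COc1cc(-c2nnc(SCC(=O)c3ccc4ccccc4c3)n2-c2ccc(N(C)C)cc2)cc(OC)c1OC` differs from compound 3 as follows: naphthalen-2-yl in place of 4-fluorophenyl on a carbonyl carbon. Naphthalen-2-yl stands in place of 4-fluorophenyl on a carbonyl carbon whose other neighbour is a saturated chain carbon.

Among the measured compounds shown here, only one measured step bears directly on a change at this carbonyl carbon, and it does not involve naphthalen-2-yl. With a 1.9-fold higher number from compound 2 to compound 3 (0.28 log units; within the scatter) as the guide, no shift beyond the scatter is expected in this assay, and no direction can be assigned with confidence. The estimated step is a 1.7-fold lower number from compound 3 to compound 4 (0.23 log units; within the scatter), which remains within the scatter. For the measured compounds named here, the range is kept wide since only that one step is available. For compound 4, the expected value is 25000 nM, with an estimated range from 3000 nM to 60000 nM.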

Compound 4, half-maximal inhibitory concentration: 18100 nM
The estimate for compound 4 lay 1.4-fold (0.14 log units) above the measured number; the range from low to high includes it.
By their numbers in this assay, from the lowest: compounds 4, 2 and 3 (each within the scatter of the next, the first and the last beyond it). At a limit, above all of these: compound 1.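

Among these compounds, at the carbonyl carbon, naphthalen-2-yl in place of 4-fluorophenyl gives the first step at this position to pass the scatter in this assay: a 2.3-fold lower number from compound 3 to compound 4 (0.37 log units; beyond the scatter). The same group in place of 4-methoxyphenyl gives a 1.2-fold lower number from compound 2 to compound 4 (0.08 log units; within the scatter), so the separation holds against 4-fluorophenyl alone, and compound 4 and compound 2 stay level. With naphthalen-2-yl held on the carbonyl carbon, swapping methoxy for dimethylamino gives an at least 3.3-fold lower number from compound 1 to compound 4 (0.52 log units; beyond the scatter), but one end of this step is a limit, so it sets a bound and not a size: the limit of > 60000 nM in this assay, at which 1 of the 4 values shown sits.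

The dimethylamino step is shown only with naphthalen-2-yl, so whether it carries over to the 4-fluorophenyl or 4-methoxyphenyl compounds stays open. Every compound shown carries an aromatic group on the carbonyl carbon, so the effect of an amine or a carboxylic acid on that group, or of a longer chain in its place, also stays open.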